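From 2-chlorophenyl to 4-chlorophenyl on an amide-type nitrogen

A few compounds are considered here, and "the series" means these few. Any claim that something is new, unique, unknown or untested is made for them only; others in the source may bear on it.

Measured so far in a functional assay on NCI-H460 cells (Homo sapiens) for inhibition, read by MTT assay, with a stated time of 24 h, tested at 10 ug/mL; on this read-out lower numbers stand for less inhibition of growth and higher numbers for more inhibition of growth at the one concentration tested:
- compound 1 `O=C(CCCCC(S)CCS)Nc1ccccc1`: 8.37%
- compound 2 `O=C(CCCCC(CCSC(=O)c1ccccc1)SC(=O)c1ccccc1)Nc1ccccc1Cl`: 12.1%

Compound 2 stands at 12.1% and compound 1 at 8.37%, so the two values lie within the scatter of each other. Among the measured compounds shown here, the two compounds differ in more than one place, so no measured single-place step is available to guide the next call.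

Compound 3 `O=C(CCCCC(CCSC(=O)c1ccccc1)SC(=O)c1ccccc1)Nc1ccc(Cl)cc1` has 4-chlorophenyl in place of 2-chlorophenyl on an amide-type nitrogen. In this assay no step beyond the scatter is expected, so the estimate stays anchored on compound 2 at 12.1%. The expected step is a number 0.9 percentage points higher from compound 2 to compound 3 (within the scatter), an estimate that lies within the scatter. The estimated value for compound 3 is 13%, with an expected range of 4% to 25%.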

Compound 3, percent growth inhibition at one concentration: 12.6%
Beside the measured number, compound 3's estimate is 0.4 percentage points above it; measured number inside the range.
By their numbers in this assay, from the lowest: compounds 1, 2 and 3 (each within the scatter of the next).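

In this assay, among the compounds shown here, 4-chlorophenyl in place of 2-chlorophenyl on an amide-type nitrogen gives a number 0.5 percentage points higher from compound 2 to compound 3 (within the scatter) and is the first single-place step available. At this one concentration, the two chlorophenyl isomers on this nitrogen therefore cannot be told apart, although this one pair says nothing about other groups at the same place. No supporting measurement bears on this result.

Going by these compounds, whether an amine or a carboxylic acid on the phenyl ring, or a pyridyl ring in its place, would give a step beyond the scatter remains open. On these data alone, the separate contributions of the chlorine and the benzoyl groups also remain open, as compound 1 and compound 2 differ in more than one place.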